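Dimethoxyphenyl in Place of Dichlorophenyl on the Carbonyl Carbon

The compounds below may be only part of what the source reports. "The series", "measured", "known", "first", "only" and "open" are said of these compounds alone.

Three compounds with a shared core have been examined in a functional assay on HCT-116 cells (Homo sapiens) for cytotoxicity, read by sulforhodamine B assay, with a stated time of 48 h, tested at 0.1 uM; a higher number here means a weaker effect of the compound at the concentration tested, a lower number a stronger effect. Compound 1 `COc1ccc(-c2cc(/C=C/C(=O)c3ccc(OC)c(OC)c3)[nH]n2)cc1` gives 105%. Compound 2 `COc1cc(-c2cc(/C=C/C(=O)c3ccc(Cl)c(Cl)c3)[nH]n2)cc(OC)c1OC` gives 100% in this assay, the second highest of the three numbers; its nearest neighbour is compound 1, whose number is higher by an amount within the scatter, while its furthest neighbour, compound 3 `COc1ccc(-c2cc(/C=C/C(=O)c3cc(OC)c(OC)c(OC)c3)[nH]n2)cc1OC`, gives 88% in this assay, a number lower by more than the scatter. Compound 4 `COc1ccc(C(=O)/C=C/c2cc(-c3cc(OC)c(OC)c(OC)c3)n[nH]2)cc1OC` remains to be measured. It differs from compound 2 in one place: 3,4-dimethoxyphenyl in place of 3,4-dichlorophenyl on a carbonyl carbon. Within the data shown here, no step between two measured compounds describes such a change alone, so the expectation rests on the whole set, in which all three numbers sit near full activity. Compound 4 is expected to give about 96% in this assay, within a range from 80% to 110%. The expected step of a number 4 percentage points lower from compound 2 to compound 4 (within the scatter) is therefore small and lies within the scatter, with no clear direction.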

Compound 4, a percentage reported as activity, at one concentration (the size of the read-out at that concentration, not a potency): 100%
For compound 4 the middle estimate is 4 percentage points below the measured one; measured number inside the range.
By their numbers in this assay, from the lowest: compound 3; then compounds 2, 4 and 1 (each within the scatter of the next).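

Among these compounds, exchanging 3,4-dichlorophenyl for 3,4-dimethoxyphenyl on a carbonyl carbon gives no change at the digits printed from compound 2 to compound 4 (within the scatter) in this assay, the first single change in this set that can be read. At this position, a group counted with 2 hydrogen-bond acceptors thus replaces one counted with 0 without moving the read-out beyond the scatter, and compound 4 gives 100%, so this change brings out no effect at the one concentration tested. No measurement shown accounts for this outcome. From the compounds shown here alone, it remains open whether a phenyl group carrying an amine or a carboxylic acid on this carbonyl carbon would shift the number. Going by these compounds, it is also open whether 3,4-dichlorophenyl and 3,4-dimethoxyphenyl would remain level at another concentration.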